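The source may report more compounds than this note shows. Statements on the series, on what has been measured and on what is new or still open speak of the compounds shown alone.

Measured so far:
Compound 1, `CN(C)CCC(NC(=O)C#Cc1ccccc1)c1ccc(Cl)cc1`: 398 nM
Compound 2, `CN(C)CCC(NC(=O)/C=C/c1ccc(C(F)(F)F)cc1)c1ccc2ccccc2c1`: 135 nM
Compound 3, `CN(C)CCC(NC(=O)/C=C/c1ccccc1)c1ccc2ccccc2c1`: 589 nM

In a functional assay on NIH3T3 cells for agonist activity at Urotensin-2 receptor (Homo sapiens), with a stated time of 5 days (a lower number here means that less compound is needed, a higher number that more compound is needed for the effect), compound 1 gives 398 nM, the second highest of the three numbers. Compound 3 gives 589 nM, within the scatter of compound 1, while compound 2 gives 135 nM, beyond the scatter below it.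

Compound 4, `CN(C)CCC(NC(=O)CCc1ccccc1)c1ccc(Cl)cc1`, has not yet been measured. It differs from compound 1 in one place: phenethyl in place of 2-phenylethynyl on a carbonyl carbon. The triple bond is thus replaced by a saturated two-carbon chain carrying the same ring.

Among the measured compounds shown here, only one measured step exists, a 4.4-fold higher number from compound 2 to compound 3 (0.64 log units; beyond the scatter), and it concerns a substituent on the distant ring, not the link between ring and carbonyl. For the measured compounds named here, no measured pair shows the effect of saturating that link. Compounds 2 and 3 carry a double bond there and compound 1 a triple bond, but they also differ in their cores, so their values alone cannot separate the two changes. Without a bearing step, the expectation for compound 4 is a modest rise with wide uncertainty, a 2.5-fold higher number from compound 1 to compound 4 (0.40 log units; beyond the scatter). Compound 4 is therefore estimated at 1000 nM, in the range 300 nM to 4000 nM.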

Compound 4, half-maximal effective concentration: 1660 nM
Estimate against measurement, compound 4: 1.7-fold (0.22 log units) below, and the stated range covers the measured number.
By their numbers in this assay, from the lowest: compound 2; then compounds 1 and 3 (each within the scatter of the next); then compound 4.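

In this assay, among the compounds shown here, the step of a 4.2-fold higher number from compound 1 to compound 4 (0.62 log units; beyond the scatter) is the first measured change at the group on the carbonyl carbon, and it goes to a higher number, so more compound is needed for the effect. Both groups have the same count of heavy atoms and the same aromatic ring, and the count differs only in the triple bond, present in 2-phenylethynyl and absent in phenethyl. That makes this pair a clean test of the link to the ring, yet no measurement at hand explains the shift.

Still open, as far as these compounds go, is where a double bond, as in compounds 2 and 3, would fall on the core of compound 1. Also open, from the compounds shown here alone, is how a longer chain on the carbonyl carbon, or an amine or carboxylic acid on the phenethyl ring, would behave.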